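The source may hold more compounds than are shown below. What is called first, only, known or untested is meant among the compounds shown, and "the series" means these compounds.

Compound 1 `Cc1cc(Nc2cc(-c3ccccc3)[nH]n2)n2nc(SCc3c(Cl)cccc3Cl)nc2n1` and compound 2 `Cc1cc(Nc2cc(-c3ccccc3)[nH]n2)n2nc(SCc3ccc([N+](=O)[O-])cc3)nc2n1` share one core and differ only in the group on the saturated chain carbon bound to a sulfur. In an ADME assay on GES1 cells (Homo sapiens) for inhibition, read by MTT assay, with a stated time of 72 h (a lower number here means a stronger inhibitor, a higher number a weaker inhibitor), compound 1 gives 39600 nM, and compound 2 gives 43600 nM, so the two numbers lie within the scatter of each other, as the step of a 1.1-fold higher number from compound 1 to compound 2 (0.04 log units; within the scatter) shows. Compound 3 `Cc1cc(Nc2cc(-c3ccccc3)[nH]n2)n2nc(SCc3nc4ccccc4[nH]3)nc2n1` changes the same place: 1H-benzimidazol-2-yl in place of 2,6-dichlorophenyl on a saturated chain carbon bound to a sulfur. Going by the values given here, the only step known concerns a different replacement at that place and was small, so it gives little guidance, and no step beyond the scatter is expected as a 1.0-fold lower number from compound 1 to compound 3 (0.02 log units; within the scatter). Compound 3 is therefore estimated at 38000 nM, within 12000 nM to 110000 nM.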

Compound 3, half-maximal inhibitory concentration: 27800 nM
Estimate against measurement, compound 3: 1.4-fold (0.14 log units) above; measured number inside the range.
By their numbers in this assay, from the lowest: compounds 3, 1 and 2 (each within the scatter of the next).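

In this assay, the 1H-benzimidazol-2-yl group adds a five-membered aromatic ring with hetero atoms, a hydrogen-bond donor and a hydrogen-bond acceptor at this place, yet a 1.4-fold lower number from compound 1 to compound 3 (0.15 log units; within the scatter) and a 1.6-fold lower number from compound 2 to compound 3 (0.20 log units; within the scatter). This place on a saturated chain carbon bound to a sulfur has therefore now carried three different groups with no step beyond the scatter. Nothing available accounts for these numbers. Going by these compounds, whether an amine, a carboxylic acid or a longer chain here would give a step beyond the scatter remains open.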